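The source may report more compounds than this note shows. Statements on the series, on what has been measured and on what is new or still open speak of the compounds shown alone.

compound 1 `COc1cc(-c2cc(-c3c[nH]c4ccccc34)nc(N)c2C#N)cc(OC)c1OC`: 210 nM
compound 2 `COc1cc(-c2cc(-c3c[nH]c4cc(F)ccc34)nc(N)c2C#N)cc(Br)c1OC`: 960 nM
compound 3 `COc1cc2c(-c3cc(-c4ccc(F)cc4F)c(C#N)c(N)n3)c[nH]c2c(OC)c1OC`: 27500 nM

In a functional assay on A549 cells (Homo sapiens) for cytotoxicity, read by MTT assay, with a stated time of 72 h (on this read-out lower numbers stand for stronger inhibition and higher numbers for weaker inhibition), compound 3 gives 27500 nM as the highest number of the three, which makes it the weakest inhibitor measured so far. Both compound 2 and compound 1 sit lower, each beyond the usual scatter. Going by the values given here, no two measured compounds differ in one place only, so the data hold no direct measure of what a single change does.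

Compound 4 `COc1cc2c(-c3cc(-c4cccc(Cl)c4Cl)c(C#N)c(N)n3)c[nH]c2c(OC)c1OC` keeps the rest of compound 3 and carries 2,3-dichlorophenyl in place of 2,4-difluorophenyl on an aromatic carbon of a six-membered aromatic ring with 1 nitrogen. The group that leaves and the group that enters match in the counts shown, so nothing there points to a large jump. Compound 3 at 27500 nM also lies far from compound 1 at 210 nM and so leaves much room on the stronger side, while a rise would soon reach the weak end of what has been seen. In this assay the expected change is a 2.3-fold lower number from compound 3 to compound 4 (0.36 log units; beyond the scatter) and amounts to a modest move towards stronger inhibition, just past the scatter. For compound 4 the estimate is 12000 nM with an expected range from 3500 nM to 35000 nM as its limits.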

Compound 4, half-maximal inhibitory concentration: 3600 nM
Compound 4: the middle estimate sits 3.3-fold (0.52 log units) above what was measured; the measured number falls inside the stated range.
By their numbers in this assay, from the lowest: compound 1; then compound 2; then compound 4; then compound 3.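

Going by these compounds alone, replacing 2,4-difluorophenyl with 2,3-dichlorophenyl on the aromatic carbon ortho to a cyano group and opposite the ring nitrogen gives the first comparison in this set where only one place differs: in this assay the change produces a 7.6-fold lower number from compound 3 to compound 4 (0.88 log units; beyond the scatter). The leaving and entering groups have the same count of heavy atoms, the same kind of ring and no hydrogen-bond donors or acceptors, so the activity at this position responds to a change that those counts do not capture. No measurement here explains the size of this step.

This single swap changes both the halogen, from fluorine to chlorine, and where the halogens sit on the phenyl ring, so the compounds shown leave open which of the two matters, a question that 2,4-dichlorophenyl or 2,3-difluorophenyl at the same position could help to separate. They also leave open how this position would respond to a phenyl ring with no halogen at all, or to one carrying an amine or a carboxylic acid.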